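Compound 3 to compound 4: methylsulfonyl replaces fluoromethyl

The source may hold more compounds than are shown below. What is called first, only, known or untested is meant among the compounds shown, and "the series" means these compounds.

Values so far, all from an ADME assay on HEp-2 cells (Homo sapiens) for cytotoxicity (on this read-out higher numbers stand for lower toxicity in this test and lower numbers for higher toxicity in this test), as read:
- compound 1 `CC(C)CCn1c(CN2C(=O)N(CC(=O)O)S(=O)(=O)c3ccccc32)nc2ccccc21` gives 60200 nM
- compound 2 `CC(C)CCn1c(CN2C(=O)C(Cc3ccccc3)C(=O)c3ccccc32)nc2ccccc21` gives 20100 nM
- compound 3 `CN1C(=O)N(Cc2nc3ccccc3n2CCCCF)c2ccccc2S1(=O)=O` gives 87700 nM

Compound 3 at 87700 nM and compound 1 at 60200 nM lie within the scatter of each other. Compound 2 at 20100 nM lies lower than compound 3, beyond the scatter.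

Compound 4 `CN1C(=O)N(Cc2nc3ccccc3n2CCCS(C)(=O)=O)c2ccccc2S1(=O)=O` keeps the core of compound 3 and alters the chain end. The change is methylsulfonyl in place of fluoromethyl on a saturated chain carbon, three bonds along the chain from an aromatic nitrogen and it turns 4-fluorobutyl into 3-(methylsulfonyl)propyl.

Going by the values given here, no measured pair in this set differs in one place only, so there is no direct precedent for this change. The expectation therefore rests on compound 3 at 87700 nM as the closest measured structure. No shift beyond the scatter is expected, and no firm direction either. The estimate means an expected 1.0-fold higher number from compound 3 to compound 4 (0.01 log units; within the scatter) in this read-out. For compound 4 the estimated value is 90000 nM with an expected range of 40000 nM to 200000 nM in this assay when it is measured.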

Compound 4, half-maximal cytotoxic concentration: 34500 nM
Estimate against measurement, compound 4: 2.6-fold (0.42 log units) above, and the stated range ends above it.
By their numbers in this assay, from the lowest: compounds 2, 4, 1 and 3 (each within the scatter of the next, the first and the last beyond it).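

In this assay, the chain end on the shared core is not silent: methylsulfonyl in place of fluoromethyl on a saturated chain carbon, three bonds along the chain from an aromatic nitrogen, gives a 2.5-fold lower number from compound 3 to compound 4 (0.41 log units; beyond the scatter), towards higher toxicity in this test. Going by these compounds alone, this is the first pair that differs in one place, and so the first reading of this position on its own. No measurement at hand bears on what lies behind the shift.

Still open is whether the step follows the entering methylsulfonyl or the departing fluoromethyl, with 4-fluorobutyl and 3-(methylsulfonyl)propyl the only chains shown on this core. A carboxylic acid or an amine at the chain end, or a longer chain, would show how far this position moves the read-out.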